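Fluoro to chloro on the far aromatic ring

The source may hold more compounds than are shown below. What is called first, only, known or untested is meant among the compounds shown, and "the series" means these compounds.

Among the compounds with values here, in a functional assay on RS4-11 cells (Homo sapiens) for inhibition, read by CCK-8 assay, with a stated time of 48 h, tested at 20 uM (a higher number here means more inhibition of growth at the concentration tested, a lower number less inhibition of growth), compound 1 `COc1ccc(S(=O)(=O)Oc2ccccc2/C=C(\C#N)C(=O)Nc2nnc(Cc3ccc(F)cc3)s2)cc1` gives 76% and stands highest of the three tested so far. Compound 2 `N#C/C(=C\c1ccccc1OS(=O)(=O)c1ccc([N+](=O)[O-])cc1)C(=O)Nc1nnc(Cc2ccc(F)cc2)s1` gives 55% and compound 3 `N#C/C(=C\c1ccccc1OS(=O)(=O)c1ccccc1[N+](=O)[O-])C(=O)Nc1nnc(Cc2ccc(F)cc2)s1` gives 61% on the same measure. The data show a number 6 percentage points higher from compound 2 to compound 3 (within the scatter) and also a number 15 percentage points lower from compound 1 to compound 3 (beyond the scatter) which places the starting point of this step level with one neighbour and clearly under the other.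

The next molecule is compound 4 `N#C/C(=C\c1ccccc1OS(=O)(=O)c1ccccc1[N+](=O)[O-])C(=O)Nc1nnc(Cc2ccc(Cl)cc2)s1` and it differs from compound 3 by chloro in place of fluoro on an aromatic carbon which means chloro in place of fluoro on an aromatic carbon, turning 4-fluorobenzyl into 4-chlorobenzyl.

Within the data shown here, no measured step touches this spot. All three changed the group on the sulfonyl sulfur, so they show only how far a single change has moved the number in this small set, and a number 21 percentage points lower from compound 1 to compound 2 (beyond the scatter) is the largest of them. Nothing measured points to a direction for the new swap, so the expectation stays anchored on compound 3 at 61% with no shift beyond the scatter. The expected step is a number 2 percentage points higher from compound 3 to compound 4 (within the scatter) and it stays small. For compound 4 the estimated value is 63% with 47% to 78% as the expected range.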

Compound 4, percent growth inhibition at one concentration: 65%
Beside the measured number, compound 4's estimate is 2 percentage points below it; the measured number falls inside the stated range.
By their numbers in this assay, from the lowest: compounds 2, 3 and 4 (each within the scatter of the next); then compound 1.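

Within the data shown here, this step is the first to touch the far aromatic ring, as every earlier step changed the group on the sulfonyl sulfur. In this assay, turning 4-fluorobenzyl into 4-chlorobenzyl gives a number 4 percentage points higher from compound 3 to compound 4 (within the scatter), so on this aromatic carbon, para to a large group, the two halogens cannot be told apart by this read-out at the single concentration tested. Nothing available here bears on what lies behind this result.

Fluoro and chloro are the only groups shown at this position, so it remains open whether an amine, a carboxylic acid or a longer chain placed there would shift growth inhibition beyond the scatter or leave it level. The chloro is also shown only alongside the 2-nitrophenyl group on the sulfonyl sulfur, which leaves open whether the same swap would be just as silent alongside the 4-methoxyphenyl group of compound 1.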